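Removing the chloro next to trifluoromethyl: activity expected unchanged

The compounds below may be only part of what the source reports. "The series", "measured", "known", "first", "only" and "open" are said of these compounds alone.

Of the compounds shown here, two have been measured in a functional assay on LOX IMVI cells (Homo sapiens) for inhibition, read by sulforhodamine B assay, with a stated time of 48 h, tested at 0.01 uM; a higher number here means a weaker effect of the compound at the concentration tested, a lower number a stronger effect. Compound 1, `O=C(Nc1cccc(-n2cc(-c3ccncc3)c(-c3cc(O)cc(Cl)c3)n2)c1)Nc1ccc(Cl)c(C(F)(F)F)c1`, gives 90% in this assay. Compound 2, `COc1cc(Cl)cc(-c2nn(-c3cccc(NC(=O)Nc4ccc(Cl)c(C(F)(F)F)c4)c3)cc2-c2ccncc2)c1`, gives 98% in this assay. Within the data shown here, the single measured step, a number 8 percentage points higher from compound 1 to compound 2 (within the scatter), lies within the scatter, so the two numbers cannot be told apart, and compound 2 stands together with compound 1 at the weak end of effect at this concentration.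

Compound 3, `COc1cc(Cl)cc(-c2nn(-c3cccc(NC(=O)Nc4cccc(C(F)(F)F)c4)c3)cc2-c2ccncc2)c1`, differs from compound 2 by hydrogen in place of chloro on an aromatic carbon. Among the measured compounds shown here, no measured step touches this position, so nothing among the measured pairs bears directly on it; the only guidance is that the one change tried so far moved nothing beyond the scatter. The step from compound 2 to compound 3 in this assay is therefore expected to be small, a number 3 percentage points lower from compound 2 to compound 3 (within the scatter). Compound 3 is estimated to give 95%, within a range from 80% to 105%.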

Compound 3, a percentage reported as activity, at one concentration (the size of the read-out at that concentration, not a potency): 96%
Compound 3: the middle estimate sits 1 percentage points below what was measured; the range from low to high includes it.
By their numbers in this assay, from the lowest: compounds 1, 3 and 2 (each within the scatter of the next).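

In this assay, going from the 4-chloro-3-(trifluoromethyl)phenyl group to the 3-(trifluoromethyl)phenyl group gives a number 2 percentage points lower from compound 2 to compound 3 (within the scatter). Among these compounds, this is the first change on the ring that carries the trifluoromethyl group, and it shows that chloro and hydrogen on this aromatic carbon cannot be told apart at this one low concentration, where compound 1, compound 2 and compound 3 all show little effect. Nothing available here explains this lack of a difference.

On these data alone, it remains open whether a different group on this aromatic carbon, such as an amine or a methoxy group, would move the number beyond the scatter. Also open, as far as these compounds go, is whether the trifluoromethyl group itself matters, which a compound carrying a nitrile or a methyl group in its place could test.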